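From 2-methylbenzyl to 2-methoxybenzyl: what to expect

This account rests on a few compounds, and the source may have more. Where it says the series, first, only, none or still open, it means among the compounds named here.

Of the compounds shown here, three with a shared core have been measured so far in an ADME assay on HEK293 cells (Homo sapiens) for cytotoxicity, read by MTT assay, with a stated time of 24 h (on this read-out lower numbers stand for stronger inhibition and higher numbers for weaker inhibition), and they do not all sit together. Compound 1 `CN(C)CCCNc1nc2cc([N+](=O)[O-])ccc2nc1NCc1ccc(C(F)(F)F)cc1` gives 5.66 ug/mL in that test and compound 2 `CN(C)CCCNc1nc2cc([N+](=O)[O-])ccc2nc1NCc1ccc(F)cc1` gives 4.28 ug/mL there, two numbers within the usual scatter of each other. Compound 3 `Cc1ccccc1CNc1nc2ccc([N+](=O)[O-])cc2nc1NCCCN(C)C` has the highest number of the three at 27.6 ug/mL in the same test.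

The next compound is compound 4 `COc1ccccc1CNc1nc2ccc([N+](=O)[O-])cc2nc1NCCCN(C)C` and it carries methoxy in place of methyl on an aromatic carbon, ortho to a large group. The counted difference reads methoxy in place of methyl on an aromatic carbon in full.

Among the measured compounds shown here, no measured step makes exactly this exchange. The closest one also swaps one group on an aromatic carbon, and it gives a 1.3-fold lower number from compound 1 to compound 2 (0.12 log units; within the scatter) as its result. Bigger moves came with replacing the whole substituted phenyl group, namely a 4.9-fold higher number from compound 1 to compound 3 (0.69 log units; beyond the scatter) and a 6.4-fold higher number from compound 2 to compound 3 (0.81 log units; beyond the scatter) in turn, and compound 4 keeps the 2-substituted pattern of compound 3. So no step beyond the scatter is expected in this assay and a slightly lower number is the likelier direction. The expected change is a 1.4-fold lower number from compound 3 to compound 4 (0.14 log units; within the scatter) as an estimate. For compound 4 the estimated value is 20 ug/mL with an expected range from 8 ug/mL to 42 ug/mL as its span.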

Compound 4, half-maximal inhibitory concentration: 36.1 ug/mL
Compound 4: middle estimate off by 1.8-fold (0.26 log units), on the low side; measured number inside the range.
By their numbers in this assay, from the lowest: compounds 2 and 1 (each within the scatter of the next); then compounds 3 and 4 (each within the scatter of the next).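

In this assay, methoxy in place of methyl on an aromatic carbon, ortho to a large group, adds one oxygen and one hydrogen-bond acceptor, yet it gives only a 1.3-fold higher number from compound 3 to compound 4 (0.12 log units; within the scatter) and so leaves the number essentially where it was. The larger gaps still follow the whole substituted phenyl group, with an 8.4-fold higher number from compound 2 to compound 4 (0.93 log units; beyond the scatter) and a 6.4-fold higher number from compound 1 to compound 4 (0.80 log units; beyond the scatter) placing the 2-methoxyphenyl compound with its 2-methylphenyl partner and well apart from the 4-fluorophenyl and 4-(trifluoromethyl)phenyl pair. No measurement offered here explains why this exchange changes so little or why the two pairs sit apart.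

Among these four compounds, the two groups with a substituent ortho to a large group are also the two with methyl or methoxy, while the other two carry fluoro or trifluoromethyl, so the place of the substituent and its identity cannot be separated. As far as these compounds go, it also remains open whether a hydroxyl, an amine or a carboxylic acid on this same aromatic carbon would stay as close to methyl as methoxy does.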